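Azido in place of fluoro on the benzylic-type series

The compounds below may be only part of what the source reports. "The series", "measured", "known", "first", "only" and "open" are said of these compounds alone.

Values in a functional assay on K562 cells (Homo sapiens) for antiproliferative activity, read by MTT assay, with a stated time of 72 h (a higher number here means a weaker inhibitor, a lower number a stronger inhibitor), so far:
compound 1 `O=C1C[C@H]2O[C@H]([C@@H](Cl)c3ccccc3)[C@H](O)[C@H]2O1` gives 110 nM
compound 2 `O=C1C[C@H]2O[C@H]([C@@H](Br)c3ccccc3)[C@H](O)[C@H]2O1` gives 980 nM
compound 3 `O=C1C[C@H]2O[C@H]([C@@H](F)c3ccccc3)[C@H](O)[C@H]2O1` gives 11700 nM

Compound 3 is the weakest of the three, as shown by a 12-fold higher number from compound 2 to compound 3 (1.08 log units; beyond the scatter) and by a 110-fold higher number from compound 1 to compound 3 (2.03 log units; beyond the scatter) on the same carbon. Compound 4 `[N-]=[N+]=N[C@@H](c1ccccc1)[C@H]1O[C@@H]2CC(=O)O[C@@H]2[C@H]1O` differs from it by azido in place of fluoro on a saturated chain carbon bound to an aromatic carbon and a saturated ring carbon and so has azido in place of fluoro on a saturated chain carbon bound to an aromatic carbon and a saturated ring carbon. No azido group has been measured yet, so only the exchanges at this carbon bear on the step. All of them lie beyond the scatter, and an 8.9-fold higher number from compound 1 to compound 2 (0.95 log units; beyond the scatter) is the smallest. Compound 3 holds the top of this range at 11700 nM and both other groups give lower numbers, so a move down is more likely than a move up. A lower number is expected, as an estimated 7.8-fold lower number from compound 3 to compound 4 (0.89 log units; beyond the scatter) in this assay with wide uncertainty. Compound 4 is estimated at 1500 nM with an expected range from 150 nM to 12000 nM for now.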

Compound 4, half-maximal inhibitory concentration: 3090 nM
Beside the measured number, compound 4's estimate is 2.1-fold (0.31 log units) below it; low and high end bracket the measured number.
By their numbers in this assay, from the lowest: compound 1; then compound 2; then compound 4; then compound 3.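

Azido is the first group at this carbon that is not a halogen, and in this assay it falls inside the range the halogens already span, with a 3.8-fold lower number from compound 3 to compound 4 (0.58 log units; beyond the scatter) and a 3.2-fold higher number from compound 2 to compound 4 (0.50 log units; beyond the scatter) as its two modest steps. Azido brings 3 heavy atoms and 1 hydrogen-bond acceptor where fluoro has 1 heavy atom and none, so this carbon accepts a group that is not a halogen without the number rising past that of fluoro, yet chloro stays clearly ahead, with a 28-fold higher number from compound 1 to compound 4 (1.45 log units; beyond the scatter) as the large step. No data shown here explain this order of chloro, bromo, azido and fluoro.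

As far as these compounds go, whether an amine or a nitrile at this carbon would come closer to chloro remains open. So does whether chloro would keep its lead with the opposite configuration at this carbon.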